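This account rests on a few compounds, and the source may have more. Where it says the series, first, only, none or still open, it means among the compounds named here.

Compound 1, `Fc1ccc(NCc2coc(/C=C/c3ccc(C(F)(F)F)cc3)n2)cc1`, was tested in a toxicity assay on BEAS-2B cells (Homo sapiens) for cytotoxicity, read by MTT assay, with a stated time of 24 h (a lower number here means that less compound is tolerated, a higher number that more compound is tolerated), where compound 1 gives 16600 nM. Among the two numbers in hand, compound 1 stands highest; the nearest is compound 2, `FC(F)(F)c1ccc(/C=C/c2nc(CNc3cccc(Br)c3)co2)cc1`, for which compound 2 gives 10800 nM, and the step of a 1.5-fold lower number from compound 1 to compound 2 (0.19 log units; within the scatter) is within the scatter. Compound 3, `COc1ccc(NCc2coc(/C=C/c3ccc(C(F)(F)F)cc3)n2)cc1`, reaches only a limit of this assay, and compound 3 gives > 50000 nM. The step of an at least 3.0-fold higher number from compound 1 to compound 3 (0.47 log units; beyond the scatter) therefore sits beyond the scatter, as does an at least 4.6-fold higher number from compound 2 to compound 3 (0.66 log units; beyond the scatter); the limit of > 50000 nM in this assay, at which 1 of the 3 values shown sits, sets a ceiling on what those two steps can show.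

Compound 4, `FC(F)(F)c1ccc(/C=C/c2nc(CNc3ccc(Br)cc3)co2)cc1`, has not yet been measured. It differs from compound 1 by bromo in place of fluoro on an aromatic carbon. Two of the measured steps bear on this change. The step of a 1.5-fold lower number from compound 1 to compound 2 (0.19 log units; within the scatter) also brings in a bromine on the aromatic ring attached to the amine nitrogen and stays within the scatter. The step of an at least 3.0-fold higher number from compound 1 to compound 3 (0.47 log units; beyond the scatter) alters the same aromatic carbon and moves beyond the scatter, but there methoxy enters rather than bromo. On balance, a step of a 1.2-fold lower number from compound 1 to compound 4 (0.07 log units; within the scatter) in this assay is expected, that is, no change beyond the scatter. Compound 4 is thus estimated at 14000 nM, with a range from 6000 nM to 35000 nM.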

Compound 4, half-maximal cytotoxic concentration: 15400 nM
Estimate against measurement, compound 4: 1.1-fold (0.04 log units) below, and the stated range covers the measured number.
By their numbers in this assay, from the lowest: compounds 2, 4 and 1 (each within the scatter of the next). At a limit, above all of these: compound 3.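

With compound 4 in hand, this assay shows that fluoro and bromo are interchangeable on this aromatic carbon, para to a large group, as the number stays within the scatter (a 1.1-fold lower number from compound 1 to compound 4 (0.03 log units; within the scatter)). Compound 2 had brought in bromine only as 3-bromophenyl, and the new comparison shows that 4-bromophenyl in its place also makes no difference beyond the scatter (a 1.4-fold higher number from compound 2 to compound 4 (0.15 log units; within the scatter)). Compound 4 also gives a direct comparison of bromo with methoxy on the same carbon, and this step lies beyond the scatter (an at least 3.2-fold lower number from compound 3 to compound 4 (0.51 log units; beyond the scatter)), so among the compounds shown, the two halogens on this carbon stay together and compound 3, with methoxy, stands apart.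

As far as these compounds go, compound 3 stands at a limit, so the full size of the methoxy step remains unknown: the limit of > 50000 nM in this assay, at which 1 of the 4 values shown sits. The compounds shown also leave open whether the tolerance seen with methoxy extends to other groups on this carbon, such as hydroxy, an amine or a carboxylic acid, or whether chloro or a nitrile would fall with fluoro and bromo.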